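The source may hold more compounds than are shown below. What is called first, only, known or untested is meant among the compounds shown, and "the series" means these compounds.

Of the compounds shown here, two have been measured so far. In a functional assay on DU-145 cells (Homo sapiens) for inhibition, read by trypan blue exclusion, with a stated time of 96 h (a higher number here means a weaker inhibitor of growth, a lower number a stronger inhibitor of growth), compound 1 (`O=C(O)c1ccc(C(=O)/C(=C\c2ccc(Cl)c([N+](=O)[O-])c2)SCc2ccc(F)cc2)cc1`) gives 1000 nM and compound 2 (`O=C(O)c1ccc(C(=O)/C(=C\c2ccc(Br)c([N+](=O)[O-])c2)SCc2ccc(Cl)cc2Cl)cc1`) gives 1000 nM, so compound 2 stands level with compound 1 at the digits available. Compound 3 (`O=C(O)c1ccc(C(=O)/C(=C\c2ccc(Br)c([N+](=O)[O-])c2)SCc2ccc(F)cc2)cc1`) differs from compound 2 in one place, on a saturated chain carbon bound to a sulfur: 4-fluorophenyl in place of 2,4-dichlorophenyl on a saturated chain carbon bound to a sulfur. Put another way, 2,4-dichlorobenzyl gives way to 4-fluorobenzyl. Among the measured compounds shown here, no measured pair differs in one place only, so the data give no direct size for such a change. With compound 1 at 1000 nM and compound 2 at 1000 nM, nothing points to a large move, and no step beyond the scatter is expected in this assay. The estimated step is no change at the digits printed from compound 2 to compound 3 (within the scatter). For compound 3 the expected value is 1000 nM, with an estimated range from 400 nM to 2500 nM.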

Compound 3, concentration for 50% growth inhibition: 1000 nM
Estimate against measurement, compound 3: no gap at the digits printed; measured number inside the range.
By their numbers in this assay, from the lowest: compounds 1, 2 and 3 (each within the scatter of the next).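

In this assay, among the compounds shown here, the first direct reading at this position comes from putting 4-fluorophenyl in place of 2,4-dichlorophenyl on a saturated chain carbon bound to a sulfur, which gives no change at the digits printed from compound 2 to compound 3 (within the scatter). The same measurement also provides a direct reading of a second place, as bromo in place of chloro on an aromatic carbon gives no change at the digits printed from compound 1 to compound 3 (within the scatter). Neither replacement separates these compounds in this assay, and no supporting measurement is available to explain this.

For the compounds shown here, both pairs exchange only one halogen-bearing group for another, so the effect of an amine or a longer chain in place of the 4-fluorophenyl remains open. Also open, as far as these compounds go, is the effect of an amide in place of the carboxylic acid that all three compounds carry.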